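The source may report more compounds than this note shows. Statements on the series, on what has been measured and on what is new or still open speak of the compounds shown alone.

Working notes on the series. Among the compounds with values here, compound 1 `C/N=C(/NC)Nc1nc(-c2ccc(OC)cc2)c(-c2ccc(OC)cc2)s1` is the reference: in a functional assay (aorta) with Rattus norvegicus as the target (a lower number here means that less compound is needed, a higher number that more compound is needed for the effect), compound 1 gives 2.4 uM, the lowest of the three numbers so far. Compound 2 `COc1ccc(-c2nc(CNC(=O)NC(C)C)sc2-c2ccc(OC)cc2)cc1` gives 5.7 uM in this assay, and compound 3 `COc1ccc(-c2nc(C(=O)N(C)C)sc2-c2ccc(OC)cc2)cc1` gives 3 uM. The step of a 2.4-fold higher number from compound 1 to compound 2 (0.38 log units; beyond the scatter) is the only one beyond the scatter; a 1.3-fold higher number from compound 1 to compound 3 (0.10 log units; within the scatter) and a 1.9-fold lower number from compound 2 to compound 3 (0.28 log units; within the scatter) both stay within it.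

Compound 4 `COc1ccc(-c2nc(C(=O)N3CCOCC3)sc2-c2ccc(OC)cc2)cc1` is not yet measured. Relative to compound 1 the change is a group of 8 heavy atoms (5 carbon, 1 nitrogen, 2 oxygen; one six-membered non-aromatic ring with 2 hetero atoms) in place of a group of 6 heavy atoms (3 carbon, 3 nitrogen; no ring), on an aromatic carbon.

Bearing on this step is chiefly compound 3, whose dimethylcarbamoyl sits on the same aromatic carbon of the shared core and whose number differs from compound 1 only by a 1.3-fold higher number from compound 1 to compound 3 (0.10 log units; within the scatter). Compound 2 shows that a larger, chain-type replacement can cost a 2.4-fold higher number from compound 1 to compound 2 (0.38 log units; beyond the scatter), so a small upward drift is possible. Overall no step beyond the scatter is expected: the estimated step is a 1.5-fold higher number from compound 1 to compound 4 (0.16 log units; within the scatter). For compound 4 the expected value in this assay is 3.5 uM, with a range from 1.5 uM to 8 uM.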

Compound 4, concentration for half-maximal effect: < 100 uM
Compound 4 ended at the assay's limit; the forecaster's own chance of this, stated with the estimate: 5%; the middle value lies beyond the limit too.
By their numbers in this assay, from the lowest: compounds 1, 3 and 2 (each within the scatter of the next, the first and the last beyond it).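

In this assay compound 4 gives < 100 uM, which is a limit and not a number, so its steps from compound 1, compound 2 and compound 3 cannot be read. The compounds shown leave open whether (morpholin-4-yl)carbonyl on this aromatic carbon gives a number within the scatter of compound 3, which carries dimethylcarbamoyl there, or beyond it.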